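This account rests on a few compounds, and the source may have more. Where it says the series, first, only, none or still open, it means among the compounds named here.

In a functional assay on Shh Light II cells (Mus musculus) for inhibition, read by a luciferase reporter (a lower number here means a stronger inhibitor, a higher number a weaker inhibitor), compound 1 (`O=C(NC1CCS(=O)(=O)CC1)N1CCC(c2nc(-c3ccc4ccccc4n3)no2)CC1`) gives 360 nM and compound 2 (`O=C(NCC1CCC1)N1CCC(c2nc(-c3ccc4ccccc4n3)no2)CC1`) gives 410 nM on the same core. Compound 3 (`O=C(NC1CC[S+]([O-])CC1)N1CCC(c2nc(-c3ccc4ccccc4n3)no2)CC1`) gives 850 nM as the highest number of the three. Within the data shown here, compound 4 (`O=C(Nc1cccc2cccnc12)N1CCC(c2nc(-c3ccc4ccccc4n3)no2)CC1`) alters only the group on the amide-type nitrogen (a group of 10 heavy atoms (9 carbon, 1 nitrogen; one six-membered aromatic ring of carbon only, one six-membered aromatic ring with 1 hetero atom) in place of a group of 7 heavy atoms (5 carbon, 1 oxygen, 1 sulfur; one six-membered non-aromatic ring with 1 hetero atom), on an amide-type nitrogen) and quinolin-8-yl appears in no measured compound. All three measured steps change that same place, one within the scatter (a 1.1-fold higher number from compound 1 to compound 2 (0.06 log units; within the scatter)) and two modest (a 2.4-fold higher number from compound 1 to compound 3 (0.37 log units; beyond the scatter) and a 2.1-fold higher number from compound 2 to compound 3 (0.32 log units; beyond the scatter)). With compound 3 at the top of this narrow spread, a modest step to a lower number is expected in this assay rather than a large one. The expected step is (a 1.9-fold lower number from compound 3 to compound 4 (0.28 log units; within the scatter)). Compound 4 is estimated at 450 nM with an expected range (130 nM to 1500 nM).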

Compound 4, half-maximal inhibitory concentration: 1400 nM
For compound 4 the middle estimate is 3.1-fold (0.49 log units) below the measured one; low and high end bracket the measured number.
By their numbers in this assay, from the lowest: compounds 1 and 2 (each within the scatter of the next); then compounds 3 and 4 (each within the scatter of the next).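

Quinolin-8-yl is the first aromatic group shown on this amide-type nitrogen, and in this assay it gives a 1.6-fold higher number from compound 3 to compound 4 (0.22 log units; within the scatter) and so cannot be told apart from the group of compound 3. The two other groups separate from it, with a 3.4-fold higher number from compound 2 to compound 4 (0.53 log units; beyond the scatter) and a 3.9-fold higher number from compound 1 to compound 4 (0.59 log units; beyond the scatter) as modest steps, so an aromatic group at this place shows no gain over the non-aromatic ones. No evidence given here accounts for these steps. On these data alone, whether a plain phenyl or a quinolin-8-yl with its ring nitrogen moved elsewhere would match compound 4 remains open.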